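The source may report more compounds than this note shows. Statements on the series, on what has been measured and on what is new or still open speak of the compounds shown alone.

Measured compounds:
- compound 1, `CC1=C(N2CC2)C(=O)C(CC(C)OC(N)=O)=C(N2CC2)C1=O`: 5.86
- compound 2, `CC1=C(N2CC2)C(=O)C(CCC(=O)N(C)C)=C(N2CC2)C1=O`: 5.09
- compound 3, `CC(C)C1=C(N2CC2)C(=O)C(C(C)C)=C(N2CC2)C1=O`: 4.36

In a functional assay on L1210 cells (Mus musculus), with a stated time of 1 days (on this read-out higher numbers stand for higher potency (the scale is a negative logarithm) and lower numbers for lower potency), compound 1 gives 5.86, and compound 2 gives 5.09. Compound 3 stands lowest of the three numbers: its nearest neighbour is compound 2, and the gap to compound 1 is the largest, both gaps beyond the scatter.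

Going by the values given here, the single measured step, a number 0.77 log units lower from compound 1 to compound 2 (beyond the scatter), concerns a change on the saturated chain and says nothing directly about the ring substituents. Among the compounds with values here, no step measured here shows methyl in place of isopropyl on a double-bonded ring carbon. What the values do show is that compound 1 and compound 2, each carrying one methyl on the shared core, both stand well above compound 3, which carries two isopropyl groups.

Compound 4, `CC1=C(N2CC2)C(=O)C(C(C)C)=C(N2CC2)C1=O`, is unmeasured. It differs from compound 3 by methyl in place of isopropyl on a double-bonded ring carbon. Within the data shown here, with no direct step to lean on, only the contrast between the methyl-bearing compounds 1 and 2 and compound 3 suggests a direction: a modest rise in this assay is expected, with wide uncertainty. The estimate for compound 4 is 4.9, within 4.2 to 5.6, which means an expected step of a number 0.54 log units higher from compound 3 to compound 4 (beyond the scatter).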

Compound 4, logarithm of the reciprocal of the active concentration, log(1/C): 4.96
The estimate for compound 4 lay 0.06 log units below the measured number; low and high end bracket the measured number.
By their numbers in this assay, from the lowest: compound 3; then compounds 4 and 2 (each within the scatter of the next); then compound 1.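

In this assay the change can now be read directly: with the aziridin-1-yl groups and the remaining isopropyl unchanged, methyl in place of isopropyl on this double-bonded ring carbon gives a modest rise beyond the scatter (a number 0.60 log units higher from compound 3 to compound 4 (beyond the scatter)). With methyl held on the other side of the shared core, the isopropyl of compound 4 and the 2-(dimethylcarbamoyl)ethyl chain of compound 2 are not separated at this position (a number 0.13 log units lower from compound 2 to compound 4 (within the scatter)), whereas the chain of compound 1 stands apart from isopropyl (a number 0.90 log units lower from compound 1 to compound 4 (beyond the scatter)). Nothing at hand gives a reason for any of these steps.

The compounds shown leave open how a plain hydrogen, an ethyl or a longer unbranched alkyl chain would stand at this position, and so whether the rise from isopropyl to methyl belongs to a wider trend. They also leave open whether an amine or a carboxylic acid at the end of the chain would stand nearer to compound 1 or to compound 4.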